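A few compounds are considered here, and "the series" means these few. Any claim that something is new, unique, unknown or untested is made for them only; others in the source may bear on it.

The measured compounds:

Compound 1, `CCOC1=C(C(=O)c2ccccc2)C(c2ccc(Br)cc2)N(CCCn2ccnc2)C1=O`, gives 35300 nM in a functional assay on A549 cells (Homo sapiens) for antiproliferative activity, read by MTT assay, with a stated time of 72 h; on this read-out higher numbers stand for weaker inhibition and lower numbers for stronger inhibition.
Compound 2, `O=C(C1=C(Nc2ccc(I)cc2)C(=O)N(CCCn2ccnc2)C1c1ccc(Br)cc1)c1ccccc1`, gives 24500 nM.
Compound 3, `O=C(C1=C(Nc2ccc(Br)cc2)C(=O)N(CCCn2ccnc2)C1c1ccc(Br)cc1)c1ccccc1`, gives 22200 nM.

Compound 3 has the lowest of the three numbers, but this says little: the step of a 1.1-fold lower number from compound 2 to compound 3 (0.04 log units; within the scatter) lies within the scatter, as does the step of a 1.6-fold lower number from compound 1 to compound 3 (0.20 log units; within the scatter). Likewise the step of a 1.4-fold lower number from compound 1 to compound 2 (0.16 log units; within the scatter) is within the scatter. All three compounds therefore sit in one narrow band.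

Compound 4, `O=C(C1=C(Nc2ccccc2Br)C(=O)N(CCCn2ccnc2)C1c1ccc(Br)cc1)c1ccccc1`, is the next compound in this series. It differs from compound 3 in one place: 2-bromophenyl in place of 4-bromophenyl on an amine nitrogen.

Two kinds of measured step bear on this change. The step from compound 2 to compound 3 exchanged one halogen for another on the same aromatic carbon and left the number essentially unchanged. The steps from compound 1 to compounds 2 and 3 replaced ethoxy with either arylamino group and also stayed within the scatter. For the measured compounds named here, no measured pair moves the bromine to a different carbon of the phenyl ring, so a direct precedent is lacking. Given how little the number has moved so far, the step of a 1.0-fold higher number from compound 3 to compound 4 (0.02 log units; within the scatter) is expected to stay within the scatter, with no clear direction.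

Compound 4 is therefore expected to give 23000 nM, with a range from 9000 nM to 60000 nM.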

Compound 4, half-maximal inhibitory concentration: 20100 nM
Beside the measured number, compound 4's estimate is 1.1-fold (0.06 log units) above it; the range from low to high includes it.
By their numbers in this assay, from the lowest: compounds 4, 3, 2 and 1 (each within the scatter of the next).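

In this assay the series now includes a change in where the bromine sits on the phenyl ring carried by the amine nitrogen, and 2-bromophenyl in place of 4-bromophenyl gives a 1.1-fold lower number from compound 3 to compound 4 (0.04 log units; within the scatter) and so stays within the same narrow band as the earlier exchange of halogens. The same holds against the iodo compound, with a 1.2-fold lower number from compound 2 to compound 4 (0.09 log units; within the scatter) as the step for 2-bromophenyl in place of 4-iodophenyl, while (2-bromophenyl)amino in place of ethoxy gives a 1.8-fold lower number from compound 1 to compound 4 (0.24 log units; within the scatter) and so behaves here like the other two arylamino groups. Nothing available explains why these changes leave the number in one band.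

From the compounds shown here alone, whether a group other than a halogen on this phenyl ring, such as a methoxy group, an amine or a carboxylic acid, would carry the number beyond the scatter remains open. So does the effect of a shorter or longer chain in place of the one on the ring nitrogen of the shared core, since that part stays the same in all four compounds.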